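Working notes: chloro for hydrogen, compound 1 to compound 3

The source may hold more compounds than are shown below. What is called first, only, known or untested is meant among the compounds shown, and "the series" means these compounds.

Measured so far:
compound 1 `O=c1cc(-c2ccccc2)oc2cc(OCCCN3CCN(c4ccccc4)CC3)ccc12`: 6.65 nM
compound 2 `Cc1ccccc1N1CCN(CCCOc2ccc3c(=O)cc(-c4ccccc4)oc3c2)CC1`: 117 nM

In a functional assay for antagonist activity at Adrenergic receptor alpha-1 (Rattus norvegicus) (a higher number here means weaker binding, a lower number tighter binding), compound 1 gives 6.65 nM, the lowest of the two numbers; compound 2 gives 117 nM. For the measured compounds named here, the only measured step, an 18-fold higher number from compound 1 to compound 2 (1.25 log units; beyond the scatter), comes from methyl in place of hydrogen on an aromatic carbon of the aryl on the piperazine. Compound 3 `O=c1cc(-c2ccc(Cl)cc2)oc2cc(OCCCN3CCN(c4ccccc4)CC3)ccc12` differs from compound 1 by chloro in place of hydrogen on an aromatic carbon. The measured step touches a different ring and does not bear directly on this change; nothing else constrains it. The expected step of a 1.1-fold higher number from compound 1 to compound 3 (0.02 log units; within the scatter) is therefore none beyond the scatter. Compound 3 is estimated at 7 nM, within 2 nM to 25 nM.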

Compound 3, dissociation constant: 8.47 nM
Beside the measured number, compound 3's estimate is 1.2-fold (0.08 log units) below it, and the stated range covers the measured number.
By their numbers in this assay, from the lowest: compounds 1 and 3 (each within the scatter of the next); then compound 2.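

Phenyl to 4-chlorophenyl gives a 1.3-fold higher number from compound 1 to compound 3 (0.11 log units; within the scatter) in this assay, so a chloro on this aromatic carbon, para to a large group, leaves the number within the scatter. For the compounds shown here, the methyl step on a different ring, an 18-fold higher number from compound 1 to compound 2 (1.25 log units; beyond the scatter), therefore has no counterpart here, although the two changes sit on different rings and are not a like-for-like comparison. Nothing available explains this result.

Still open, on these data alone, is whether this carbon also accepts a methoxy, an amine or a carboxylic acid. Chloro on the other carbons of this ring is open too.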